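Swapping the outer aryl ring on a pyridine-amide series

The source may report more compounds than this note shows. Statements on the series, on what has been measured and on what is new or still open speak of the compounds shown alone.

Measured so far in a functional assay on A549 cells (Homo sapiens) for cytotoxicity, read by MTT assay, with a stated time of 72 h; on this read-out higher numbers stand for weaker inhibition and lower numbers for stronger inhibition:
Compound 1, `O=C(Nc1ccc(Oc2ccnc3[nH]ccc23)cc1)c1ccc(-c2ccc(F)cc2F)cn1`, gives > 10000 nM, which is a limit of this assay and not a number.
Compound 2, `O=C(Nc1ccc(Oc2ccnc3[nH]ccc23)c(F)c1)c1ccc(-c2ccccc2)cn1`, gives 1250 nM.
Compound 3, `O=C(Nc1ccc(Oc2ccnc3[nH]ccc23)c(F)c1)c1ccc(-c2ccc(Cl)cc2)cn1`, gives 10000 nM.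

Among the compounds with values here, compound 3 has the highest number among the two compounds that gave a number, and the only step measured leads to it: an 8.0-fold higher number from compound 2 to compound 3 (0.90 log units; beyond the scatter). Compound 1, which also carries a 2,4-difluorophenyl group, sits at the limit (the limit of > 10000 nM in this assay, at which 1 of the 3 values shown sits).

Compound 4, `O=C(Nc1ccc(Oc2ccnc3[nH]ccc23)c(F)c1)c1ccc(-c2ccc(F)cc2F)cn1`, is not yet measured. It differs from compound 3 in one place: 2,4-difluorophenyl in place of 4-chlorophenyl on an aromatic carbon. Within the data shown here, no measured step makes exactly this change. Among the measured compounds shown here, the one step that touches this ring, from hydrogen to chloro, weakened inhibition by a modest amount, and the only compound bearing the 2,4-difluorophenyl group, compound 1, reached the limit. Taken together, these suggest that compound 4 is expected to be no stronger than compound 3 and may well reach the limit too.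

The expected step is a 1.2-fold higher number from compound 3 to compound 4 (0.08 log units; within the scatter), a change that may not rise beyond the scatter. Compound 4 is therefore estimated at 12000 nM, with a likely range from 3000 nM to 40000 nM.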

Compound 4, half-maximal inhibitory concentration: 3100 nM
Beside the measured number, compound 4's estimate is 3.9-fold (0.59 log units) above it, within the range that was stated.
By their numbers in this assay, from the lowest: compound 2; then compound 4; then compound 3.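

On the aromatic carbon two atoms from the ring nitrogen, the outer ring is not simply a place where any added halogen costs activity: in this assay, 2,4-difluorophenyl in place of 4-chlorophenyl gives a 3.2-fold lower number from compound 3 to compound 4 (0.51 log units; beyond the scatter) and recovers much of what chloro lost. Even so, the plain phenyl ring keeps the lowest number of the three, since 2,4-difluorophenyl in place of phenyl gives a 2.5-fold higher number from compound 2 to compound 4 (0.39 log units; beyond the scatter) and shows that the two fluoro atoms are not free of cost against hydrogen on that ring. The new compound also gives the first view of the other end of the molecule, where fluoro in place of hydrogen on the shared core gives an at least 3.2-fold lower number from compound 1 to compound 4 (0.50 log units; beyond the scatter) with the outer ring held constant, though compound 1 stands at a limit and not at a number: the limit of > 10000 nM in this assay, at which 1 of the 4 values shown sits.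

Which of the two fluoro atoms accounts for the gap to the 4-chlorophenyl compound stays open. So does the question of whether the order seen here would hold for an outer ring carrying a methoxy group, an amine or a carboxylic acid.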